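The source may report more compounds than this note shows. Statements on the series, on what has been measured and on what is new or still open speak of the compounds shown alone.

Compound 3 `COc1ccc(-c2nc3cc(NC(=O)[C@H](C)Oc4cccc(F)c4F)ccc3o2)cc1` was tested in an assay on isolated protein for inhibition of GMP reductase 2 (Homo sapiens), read by spectrophotometry; a higher number here means a weaker inhibitor, a lower number a stronger inhibitor. In this assay compound 3 gives only a limit, > 5000 nM. Compound 1 `C[C@H](Oc1cccc(Cl)c1Cl)C(=O)Nc1ccc2oc(-c3ccc(F)cc3)nc2c1` also returns only a limit in this assay, > 5000 nM. Compound 2 `COc1ccc(Cc2nc3cc(NC(=O)[C@H](C)Oc4cccc(Cl)c4Cl)ccc3o2)cc1` likewise gives a limit in this assay, > 5000 nM. Among the measured compounds shown here, the single step between measured compounds that differ in one place, a step that the two limits leave unreadable from compound 1 to compound 2, puts 4-methoxybenzyl in place of 4-fluorophenyl on an aromatic carbon, and its size cannot be read since (the limit of > 5000 nM in this assay, at which 3 of the 3 values shown sit).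

Compound 4 `COc1ccc(-c2nc3cc(NC(=O)[C@H](C)Oc4cccc(Cl)c4Cl)ccc3o2)cc1` has not yet been measured. It differs from compound 3 in one place: 2,3-dichlorophenyl in place of 2,3-difluorophenyl on an oxygen on a saturated carbon. For the measured compounds named here, no measured step involves this exchange of 2,3-dichlorophenyl for 2,3-difluorophenyl on an oxygen on a saturated carbon, so nothing measured bears on it directly. Going by the values given here, the only comparison available is that compound 2, which carries the 2,3-dichlorophenoxy group, and compound 3, which carries the 2,3-difluorophenoxy group, both sit at the limit.

On that basis the step from compound 3 to compound 4 is expected to be a step that the limit leaves unreadable from compound 3 to compound 4, with nothing beyond the scatter foreseen. For compound 4 the estimated value in this assay is 8000 nM, within a range from 2500 nM to 40000 nM, and it is most likely to be reported again only as a limit.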

Compound 4, inhibition constant: > 5000 nM
Compound 4: only a limit was reported (the forecaster's own chance of this, stated with the estimate: 85%); the middle value lies beyond the limit too.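

In this assay compound 4 gives only a limit, > 5000 nM. No step from compound 1, compound 2 or compound 3 to compound 4 can be read, because all the compounds share the same limit: the limit of > 5000 nM in this assay, at which 4 of the 4 values shown sit.

The compounds shown leave open whether any exchange among them, including 2,3-dichlorophenyl for 2,3-difluorophenyl, alters inhibition at all.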